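From 2-acetylethyl to cyano on compound 1

The compounds below may be only part of what the source reports. "The series", "measured", "known", "first", "only" and "open" are said of these compounds alone.

Measured in a physicochemical assay for solubility, with a stated time of 4 h, at pH 7.4; on this read-out higher numbers stand for higher solubility and lower numbers for lower solubility:
Compound 1 `CC(=O)CCc1cc(C)c(Oc2cc(Nc3ccc(C#N)cc3)c(N)cc2C(F)(F)F)c(C)c1`: 0.16 ug/mL
Compound 2 `Cc1cc(CCC#N)cc(C)c1Oc1cc(Nc2ccc(C#N)cc2)c(N)cc1CO`: 18.8 ug/mL

Compound 1 has the lower of these two numbers, and the gap up to compound 2 lies well beyond the usual scatter of repeat measurements. Compound 3 `Cc1cc(C#N)cc(C)c1Oc1cc(Nc2ccc(C#N)cc2)c(N)cc1C(F)(F)F` keeps the core of compound 1 but carries cyano in place of 2-acetylethyl on an aromatic carbon, meta to two methyl groups: cyano in place of 2-acetylethyl on an aromatic carbon.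

Among the compounds with values here, no measured pair differs in one place only, so nothing yet shows directly what a single change does in this assay. Compound 2 differs from compound 1 in more than one place, so its number offers only a loose guide. The expected move is a modest rise, a 2.5-fold higher number from compound 1 to compound 3 (0.40 log units; beyond the scatter), which may not clear the scatter. For compound 3 the estimated value is 0.4 ug/mL, with an expected range of 0.1 ug/mL to 2 ug/mL.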

Compound 3, solubility: 0.26 ug/mL
The estimate for compound 3 lay 1.5-fold (0.19 log units) above the measured number, and the stated range covers the measured number.
By their numbers in this assay, from the lowest: compounds 1 and 3 (each within the scatter of the next); then compound 2.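

Within the data shown here, this is the first pair that differs in one place only, so it gives a direct reading of a single change. In this assay, among these compounds, putting cyano in place of 2-acetylethyl on this aromatic carbon, meta to two methyl groups, gives a 1.6-fold higher number from compound 1 to compound 3 (0.21 log units; within the scatter), so shortening the substituent from 5 heavy atoms to 2 produces no step that can be told apart from repeat measurements. No available measurement offers an explanation for this result.

From the compounds shown here alone, whether an amine, a carboxylic acid or a longer chain on this same carbon would give a step beyond the scatter remains open. Also open, going by these compounds, is which of the several places that separate compound 1 from compound 2 goes with the much higher number of compound 2.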